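Carbamate series: acetyl to 2-hydroxyethyl on the distal ring

The source may hold more compounds than are shown below. What is called first, only, known or untested is meant among the compounds shown, and "the series" means these compounds.

Working notes on an assay on cell membranes for binding affinity to Fatty-acid amide hydrolase 1 (Rattus norvegicus) (on this read-out lower numbers stand for stronger inhibition and higher numbers for weaker inhibition), for three measured carbamates. Compound 1 `Cc1cccc(-c2cccc(OC(=O)NC3CCCCC3)c2)c1` gives 61.8 nM; compound 2 `O=C(NC1CCCCC1)Oc1cccc(-c2cccc(F)c2)c1` gives 96.6 nM; compound 3 `CC(=O)c1cccc(-c2cccc(OC(=O)NC3CCCCC3)c2)c1` gives 9.1 nM. Compound 3 stands lowest of the three, with the nearest, compound 1, set apart by a 6.8-fold lower number from compound 1 to compound 3 (0.83 log units; beyond the scatter) and the furthest, compound 2, by an 11-fold lower number from compound 2 to compound 3 (1.03 log units; beyond the scatter); between the two weaker members the gap is a 1.6-fold higher number from compound 1 to compound 2 (0.19 log units; within the scatter).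

Next is compound 4 `O=C(NC1CCCCC1)Oc1cccc(-c2cccc(CCO)c2)c1`, which carries 2-hydroxyethyl in place of acetyl on an aromatic carbon. Among the compounds with values here, no measured pair swaps the acetyl for a group of this kind, so the steps that bear on it are only those that put the acetyl in: from a methyl, a 6.8-fold lower number from compound 1 to compound 3 (0.83 log units; beyond the scatter), and from a fluoro, an 11-fold lower number from compound 2 to compound 3 (1.03 log units; beyond the scatter). Both show that the move to the acetyl is what separates compound 3 from the rest of the set. Taking the acetyl away again, even for a group of like size that, as counted, brings a hydrogen-bond donor, is expected to hand back part of that separation in this assay: a step upward of moderate size rather than none. For compound 4 the estimate is a 3.3-fold higher number from compound 3 to compound 4 (0.52 log units; beyond the scatter), with 30 nM expected and a range of 8 nM to 120 nM.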

Compound 4, half-maximal inhibitory concentration: 18.7 nM
For compound 4 the middle estimate is 1.6-fold (0.21 log units) above the measured one; the measured number falls inside the stated range.
By their numbers in this assay, from the lowest: compound 3; then compound 4; then compounds 1 and 2 (each within the scatter of the next).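

The acetyl is not required for a low number at this position: in this assay, 2-hydroxyethyl, which has no double bond outside aromatic rings and brings a hydrogen-bond donor, gives up only a modest step (a 2.1-fold higher number from compound 3 to compound 4 (0.31 log units; beyond the scatter)). It keeps most of the separation from the other two groups, both against fluoro (a 5.2-fold lower number from compound 2 to compound 4 (0.71 log units; beyond the scatter)) and against the methyl that it extends by a hydroxymethyl (a 3.3-fold lower number from compound 1 to compound 4 (0.52 log units; beyond the scatter)), so among these four compounds, the two groups that carry oxygen, in compound 3 and compound 4, both stand below methyl and fluoro, with no compound going against this. Nothing measured here accounts for the size of any of these steps.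

The compounds shown do not separate the contribution of the hydroxyl hydrogen from that of the oxygen or of the two-carbon chain, a question that 2-methoxyethyl or 2-aminoethyl at the same place would address. From the compounds shown here alone, how far this position extends to a longer chain such as 3-hydroxypropyl, or to a carboxylic acid, also remains open.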